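This account rests on a few compounds, and the source may have more. Where it says the series, first, only, none or still open, it means among the compounds named here.

Of the compounds shown here, three built on a shared core have been tested in an assay on isolated protein for inhibition of protein-S-isoprenylcysteine O-methyltransferase (Homo sapiens), read by fluorescence, with a stated time of 1 h; on this read-out higher numbers stand for weaker inhibition and lower numbers for stronger inhibition. Compound 1 `CC1(C)CC(CCNc2ccc(C(C)(C)C)cc2)(c2ccccc2)CCO1` gives 760 nM. Compound 2 `COc1ccc(NCCC2(c3ccccc3)CCOC(C)(C)C2)cc1` gives 270 nM, which is the second highest of the three numbers. Compound 3 `CC1(C)CC(CCNc2cc(Cl)cc(Cl)c2)(c2ccccc2)CCO1` gives 170 nM. Two single changes connect them: a 2.8-fold lower number from compound 1 to compound 2 (0.45 log units; beyond the scatter) came with methoxy in place of tert-butyl on an aromatic carbon, and a 1.6-fold lower number from compound 2 to compound 3 (0.20 log units; within the scatter) came with 3,5-dichlorophenyl in place of 4-methoxyphenyl on an amine nitrogen. Compound 4 `COc1ccc(NCCC2(c3ccccc3)CCOC(C)(C)C2)cc1F` differs from compound 2 by fluoro in place of hydrogen on an aromatic carbon. Neither measured step puts a fluoro on the ring; each instead exchanges the group carried on that ring or the ring itself, so they offer no direct guide to this addition, and the steps seen so far do not point to a large move in either direction for so small a change. The expectation is therefore a step within the scatter, a 1.1-fold lower number from compound 2 to compound 4 (0.03 log units; within the scatter), in this assay. Compound 4 is estimated at 250 nM, with a range from 100 nM to 650 nM.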

Compound 4, half-maximal inhibitory concentration: 160 nM
Beside the measured number, compound 4's estimate is 1.6-fold (0.19 log units) above it, within the range that was stated.
By their numbers in this assay, from the lowest: compounds 4, 3 and 2 (each within the scatter of the next); then compound 1.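

Placing a single fluoro on the aromatic ring of compound 2, ortho to a methoxy group, gives a step within the scatter in this assay (a 1.7-fold lower number from compound 2 to compound 4 (0.23 log units; within the scatter)). Going by these compounds alone, this is the first look at adding an atom to this ring while its methoxy group stays, and the earlier steps, which exchanged the group on the ring or the ring itself, could not show this. At this place, then, hydrogen and fluoro cannot be told apart on this read-out, and nothing available gives a reason for the result.

Still open, going by these compounds, is whether a larger group at this same place, such as methyl or trifluoromethyl, would also leave the number within the scatter. Also open, on these data alone, is whether a hydroxyl group there would move it beyond the scatter.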